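Shortening a carboxyalkyl side chain and solubility

The source may hold more compounds than are shown below. What is called first, only, known or untested is meant among the compounds shown, and "the series" means these compounds.

Measured compounds:
compound 1, `CCC(C(=O)O)c1nn(Cc2cn3cc(OCC4CC4)c(Cl)cc3n2)c2ccccc2c1=O`: 359 ug/mL
compound 2, `O=C(O)Cn1nc(Cc2nc3cc(F)c(OCC4CC4)cc3[nH]2)c2ccccc2c1=O`: 841 ug/mL
compound 3, `C[C@H](C(=O)O)n1nc(Cn2cc3cc(OCC4CC4)c(Cl)cc3n2)c2ccccc2c1=O`: 958 ug/mL

In a physicochemical assay for solubility, measured as thermodynamic solubility, at pH 7.4 (on this read-out higher numbers stand for higher solubility and lower numbers for lower solubility), compound 1 gives the lowest of the three numbers; compound 2 and compound 3 both sit beyond the usual scatter above it. Compound 4, `C[C@H](C(=O)O)c1nn(Cc2cn3cc(OCC4CC4)c(Cl)cc3n2)c2ccccc2c1=O`, has not yet been measured in this assay. It differs from compound 1 in a single place: 1-carboxyethyl in place of 1-carboxypropyl on an aromatic carbon. Among the measured compounds shown here, no pair of measured compounds shows exactly this step, so there is no measured guide to its size. A side chain shorter by one carbon is expected to move solubility upward only a little, if at all, so a 1.3-fold higher number from compound 1 to compound 4 (0.10 log units; within the scatter) is expected to be small and may fall within the scatter. The estimate for compound 4 in this assay is 450 ug/mL, within a range of 200 ug/mL to 1000 ug/mL.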

Compound 4, solubility: 892 ug/mL
For compound 4 the middle estimate is 2.0-fold (0.30 log units) below the measured one; the measured number falls inside the stated range.
By their numbers in this assay, from the lowest: compound 1; then compounds 2, 4 and 3 (each within the scatter of the next).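

In this assay, swapping 1-carboxypropyl for 1-carboxyethyl on this aromatic carbon gives a 2.5-fold higher number from compound 1 to compound 4 (0.40 log units; beyond the scatter), so a chain shorter by one carbon makes a difference here that stands clear of the usual scatter. The entering 1-carboxyethyl also carries a defined stereocentre and the leaving 1-carboxypropyl does not, so this step holds two differences at once. Nothing shown gives a measured reason for the step.

From the compounds shown here alone, it remains open how the mirror-image form of 1-carboxyethyl would compare. Also open, going by these compounds, is what a longer chain such as 1-carboxybutyl, or an amine in place of the carboxylic acid, would do at this position.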